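Replacing 4-hydroxybutyl with 3-hydroxyphenyl on the triple bond

The source may hold more compounds than are shown below. What is called first, only, known or untested is meant among the compounds shown, and "the series" means these compounds.

Values so far in a functional assay on NIH3T3 cells (Mus musculus) (on this read-out lower numbers stand for an effect already at smaller amounts and higher numbers for an effect only at larger amounts of compound), are these:
- Compound 1 `Cn1cncc1C(OCc1ccc(C#N)cc1C#Cc1ccccn1)c1ccc(C#N)cc1` gives > 0.1 nM as a limit
- Compound 2 `Cn1cncc1C(OCc1ccc(C#N)cc1C#Cc1ccc(-c2ccccc2)cc1)c1ccc(C#N)cc1` gives > 0.1 nM as a limit
- Compound 3 `Cn1cncc1C(OCc1ccc(C#N)cc1C#CCCCCO)c1ccc(C#N)cc1` gives 20.9 nM as a number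

Among the compounds with values here, compound 3 holds the only true number in this assay at 20.9 nM as its value. The other two results are limits, shown as the limit of > 0.1 nM in this assay, at which 2 of the 3 values shown sit, and no more than that.

Compound 4 `Cn1cncc1C(OCc1ccc(C#N)cc1C#Cc1cccc(O)c1)c1ccc(C#N)cc1` follows from compound 3 by one change 3-hydroxyphenyl in place of 4-hydroxybutyl on a triple-bonded carbon at that same triple-bonded carbon. The nearest measured steps are a step that the limit leaves unreadable from compound 1 to compound 3 and a step that the limit leaves unreadable from compound 2 to compound 3 and neither gives a size or direction. The expected change is therefore a 1.0-fold lower number from compound 3 to compound 4 (0.02 log units; within the scatter) with no direction favoured and wide uncertainty. Compound 4 is estimated at 20 nM with an expected range from 3 nM to 120 nM in this estimate.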

Compound 4, half-maximal effective concentration: > 0.1 nM
Compound 4: a limit, no number; the forecaster's own chance of this, stated with the estimate: 25%; the middle value does not contradict the limit.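

No step to compound 4 can be read from compound 1, compound 2 or compound 3, since compound 4 gives only a limit: the limit of > 0.1 nM in this assay, at which 3 of the 4 values shown sit.

The compounds shown leave open whether 3-hydroxyphenyl gives a lower or higher number than 4-hydroxybutyl.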